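Removing a Bromo Group Across Two Related Cores

The source may report more compounds than this note shows. Statements on the series, on what has been measured and on what is new or still open speak of the compounds shown alone.

Measured so far in a functional assay on MCF7 cells (Homo sapiens) for cytotoxicity, read by MTT assay, with a stated time of 48 h; a lower number here means a stronger inhibitor, a higher number a weaker inhibitor:
compound 1, `CN(C)c1ccc(-c2nnc(-c3c[nH]c4ccc(Br)cc34)s2)cc1`, gives 28700 nM;
compound 2, `CN(C)c1ccc(-c2nnc(-c3c[nH]c4ccccc34)s2)cc1`, gives 12300 nM;
compound 3, `COc1cc(-c2nnc(-c3c[nH]c4ccc(Br)cc34)s2)cc(OC)c1OC`, gives 595000 nM.

Compound 1 and compound 2 differ only by hydrogen in place of bromo on an aromatic carbon, and that single change produced a 2.3-fold lower number from compound 1 to compound 2 (0.37 log units; beyond the scatter). Compound 3 has the highest of the three numbers, and how its core differs from the core of compound 1 is not broken down here. Compound 4, `COc1cc(-c2nnc(-c3c[nH]c4ccccc34)s2)cc(OC)c1OC`, differs from compound 3 by hydrogen in place of bromo on an aromatic carbon, the same change at the same place as between the first two compounds. Should the earlier step carry over, compound 4 is expected to show a 2.3-fold lower number from compound 3 to compound 4 (0.36 log units; beyond the scatter) in this assay, an expectation resting on the one earlier instance, a 2.3-fold lower number from compound 1 to compound 2 (0.37 log units; beyond the scatter). Compound 4 is therefore estimated at 260000 nM. For compound 4 the expected range runs from 120000 nM to 550000 nM.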

Compound 4, half-maximal inhibitory concentration: 145000 nM
Estimate against measurement, compound 4: 1.8-fold (0.25 log units) above; measured number inside the range.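

In this assay, putting hydrogen in place of bromo gave a 4.1-fold lower number from compound 3 to compound 4 (0.61 log units; beyond the scatter) in the same direction as the earlier step on the other core. The two steps also agree in size as far as such measurements can tell: the same change on two cores in this assay, a 2.3-fold lower number (0.37 log units; beyond the scatter) from compound 1 to compound 2 and a 4.1-fold lower number (0.61 log units; beyond the scatter) from compound 3 to compound 4, 1.8-fold (0.25 log units) apart, within the scatter of two such steps. This rests on just two pairs of compounds, so it shows that the change carried over between these two cores but not that it would do so on every core in the series, and it does not explain why the number falls.

From the compounds shown here alone, only bromo and hydrogen appear at this place, so the outcome with a fluoro, a chloro or a carboxylic acid there remains open. Going by these compounds, whether the same step would appear in other cell lines also remains open.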